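A few compounds are considered here, and "the series" means these few. Any claim that something is new, unique, unknown or untested is made for them only; others in the source may bear on it.

Values measured in an ADME assay on HEp-2 cells (Homo sapiens) for cytotoxicity (on this read-out higher numbers stand for lower toxicity in this test and lower numbers for higher toxicity in this test), are as follows:
Compound 1 `CC(C)CCn1c(Cn2c(=O)n(C(C)C)c3ccccc32)nc2c(CN)cccc21` gives 7000 nM
Compound 2 `CC(C)CCn1c(Cn2c(=O)n(C(C)C)c3ccccc32)nc2cc(CN)ccc21` gives 3920 nM
Compound 3 `CNCc1ccc2c(c1)nc(Cn1c(=O)n(C(C)C)c3ccccc31)n2CCC(C)C` gives 1480 nM

Of these three, compound 3 has the lowest number, under those of compound 2 and compound 1. The next structure, compound 4 `CC(C)CCn1c(Cn2c(=O)n(C(C)C)c3ccccc32)nc2cc(CNC3CC3)ccc21`, carries cyclopropyl in place of methyl on an amine nitrogen. For the measured compounds named here, the one measured step that bears on this is methyl in place of hydrogen on an amine nitrogen (a 2.6-fold lower number from compound 2 to compound 3 (0.42 log units; beyond the scatter)), which was modest but beyond the scatter. Going by the values given here, no measured step starts from methyl, so only a small further fall in this assay is expected, perhaps none beyond the scatter. The expected change is a 1.2-fold lower number from compound 3 to compound 4 (0.09 log units; within the scatter) ( an estimate only ). For compound 4 the estimated value is 1200 nM (range 500 nM to 3000 nM).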

Compound 4, half-maximal cytotoxic concentration: 17200 nM
For compound 4 the middle estimate is 14-fold (1.16 log units) below the measured one; measured number outside the range, above it.
By their numbers in this assay, from the lowest: compound 3; then compounds 2 and 1 (each within the scatter of the next); then compound 4.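

In this assay, the group on this amine nitrogen does not act in one direction: methyl gave a lower number than hydrogen, whereas cyclopropyl gives a 12-fold higher number from compound 3 to compound 4 (1.07 log units; beyond the scatter) and a 4.4-fold higher number from compound 2 to compound 4 (0.64 log units; beyond the scatter). The outcome therefore depends on which group is present, not simply on whether the nitrogen carries one. Nothing available explains this reversal. As far as these compounds go, whether an ethyl or a cyclobutyl group on this nitrogen would fall with methyl or with cyclopropyl remains open. So does whether cyclopropyl would have a similar effect on the amine as it is placed in compound 1.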